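This account rests on a few compounds, and the source may have more. Where it says the series, first, only, none or still open, it means among the compounds named here.

Measured compounds in an ADME assay on HepG2 cells (Homo sapiens) for cytotoxicity, read by trypan blue exclusion, with a stated time of 48 h, in the presence of a further agent that is not named here; a higher number here means that more compound is tolerated, a lower number that less compound is tolerated:

Compound 1 `COc1ccc2nc(C)cc(OCC(=O)Nc3ccc(OC)c(OC)c3)c2c1` gives > 131000 nM in this assay, which is a limit of the assay rather than a number.

Compound 2 `COc1cc(NC(=O)COc2cc(C)nc3ccc(OC)cc23)cc(OC)c1` gives > 131000 nM in this assay, again a limit.

Compound 3 `COc1ccc2nc(C)cc(OCC(=O)Nc3cccc(Br)c3)c2c1` gives > 125000 nM in this assay, also a limit.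

Compound 3 therefore stands at a limit only: its tolerated concentration is not pinned down, and the same holds for the rest of the set, with one value at the limit of > 125000 nM in this assay, at which 1 of the 3 values shown sits, and two values at the limit of > 131000 nM in this assay, at which 2 of the 3 values shown sit. For the measured compounds named here, no step between measured compounds is available, so nothing shows a change in tolerated concentration that rises beyond the scatter.

Compound 4 `COc1ccc2nc(C)cc(OCC(=O)NCCCc3ccccc3)c2c1` differs from compound 3 by 3-phenylpropyl in place of 3-bromophenyl on an amide-type nitrogen. With every measured compound sitting at a limit, the expected step from compound 3 to compound 4 in this assay is a step that the limit leaves unreadable from compound 3 to compound 4, none beyond the scatter, with the most likely outcome again a limit rather than a number. Compound 4 is estimated at 150000 nM in this assay, within a range from 60000 nM to 400000 nM.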

Compound 4, half-maximal cytotoxic concentration: > 137000 nM
Compound 4 ended at the assay's limit; the forecaster's own chance of this, stated with the estimate: 85%; the middle value is on the limit's open side.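

Compound 3 and compound 4 both give limits rather than numbers in this assay, and the step between them cannot be read. The compounds shown leave open what concentration of any of them is actually tolerated, and whether 3-phenylpropyl in place of 3-bromophenyl changes it.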